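The source may report more compounds than this note shows. Statements on the series, on what has been measured and on what is new or still open speak of the compounds shown alone.

Measured in a functional assay on HT-29 cells (Homo sapiens) for inhibition; a higher number here means a weaker inhibitor, a lower number a stronger inhibitor:
Compound 1 `COc1ccc(/C=C/c2ccc3ccccc3c2)cc1[N+](=O)[O-]`: > 5000 nM
Compound 2 `O=S(=O)(c1ccccc1)n1ccc2cc(/C=C/c3ccc4ccccc4c3)ccc21`: > 5000 nM
Compound 3 `O=S(=O)(c1ccccc1)n1ccc2cc(/C=C\c3ccc4ccccc4c3)ccc21`: > 5000 nM

Each of these three readings is a limit and not a number. Compound 3 stands at the limit of > 5000 nM in this assay, at which 3 of the 3 values shown sit, and so has no number of its own. The unmeasured compound 4 `C(=C\c1ccc2[nH]ccc2c1)\c1ccc2ccccc2c1` differs from compound 3 in one place: hydrogen in place of phenylsulfonyl on an aromatic nitrogen gives hydrogen in place of phenylsulfonyl on an aromatic nitrogen. Within the data shown here, only one measured step lies close to this change, a step that the two limits leave unreadable from compound 2 to compound 3, and it rests on the fact that compounds 2 and 3 differ only in the configuration as drawn rather than on anything at that nitrogen. Among the measured compounds shown here, that step has no readable size, and no measured pair shows the loss of phenylsulfonyl. The data therefore give neither a size nor a direction for the step in this assay. With all three measured compounds at the limit, the plainest expectation is that compound 4 stays close to it too, although a real number remains possible and the range must stay wide. The estimated size of a number no higher from compound 3 to compound 4 (the limit leaves the size open) is accordingly no more than a rough guess. For compound 4 the expected value is 5000 nM with an estimated range from 800 nM to 20000 nM around it.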

Compound 4, half-maximal inhibitory concentration: > 5000 nM
Compound 4 gave a limit, no number; the forecaster's own chance of this, stated with the estimate: 60%; the middle value sits exactly at the limit.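

In this assay compound 4 gives > 5000 nM as a limit and not a number. Compound 3 also has only a limit, so the step between compound 3 and compound 4 cannot be read. What hydrogen in place of phenylsulfonyl on an aromatic nitrogen does to inhibition stays open, as do the actual values of all the compounds shown, which share one reading: the limit of > 5000 nM in this assay, at which 4 of the 4 values shown sit.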